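Adding a Second Chloro Where Three Compounds Show No Activity

The source may report more compounds than this note shows. Statements on the series, on what has been measured and on what is new or still open speak of the compounds shown alone.

Compound 1 `COc1ccc(/C=C/C(=O)c2sc(Nc3ccc(Cl)cc3)nc2C)cc1` was tested in a functional assay on NCI-H460 cells (Homo sapiens) for cytotoxicity, read by MTT assay; on this read-out lower numbers stand for stronger inhibition and higher numbers for weaker inhibition. In this assay compound 1 gives > 25000 nM, which is a limit of the assay rather than a number. Compound 2 `Cc1nc(Nc2ccc(Cl)cc2)sc1C(=O)/C=C/c1ccccc1` likewise stops at a limit, > 25000 nM. Compound 3 `COc1cccc(/C=C/C(=O)c2sc(Nc3ccc(Cl)cc3)nc2C)c1` also reaches only a limit, > 25000 nM. Because all three values sit at the limit of > 25000 nM in this assay, at which 3 of the 3 values shown sit, the steps among them cannot be read: a step that the two limits leave unreadable from compound 1 to compound 2, a step that the two limits leave unreadable from compound 1 to compound 3 and a step that the two limits leave unreadable from compound 2 to compound 3. Compound 1 therefore stands at the same limit as the other two, with no number to set it apart from them.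

Compound 4 `COc1ccc(/C=C/C(=O)c2sc(Nc3ccc(Cl)c(Cl)c3)nc2C)cc1` differs from compound 1 by chloro in place of hydrogen on an aromatic carbon. Among the measured compounds shown here, none of the measured steps touches this part of the molecule, and all of them are unreadable, so they give no direction for the change. The step is therefore expected to be a step that the limit leaves unreadable from compound 1 to compound 4, with the result most likely once more a limit. Compound 4 is estimated at 35000 nM, in the range 8000 nM to 150000 nM.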

Compound 4, half-maximal inhibitory concentration: > 25000 nM
Compound 4 was reported as a limit (the forecaster's own chance of this, stated with the estimate: 80%); the middle value is on the limit's open side.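

Compound 4 also ends at a limit, so its step from compound 1 cannot be read, and the second chloro yields no new comparison: the limit of > 25000 nM in this assay, at which 4 of the 4 values shown sit.

Whether the second chloro or any other change among these four compounds shifts the result in this assay stays open.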